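The source may report more compounds than this note shows. Statements on the series, on what has been measured and on what is new or still open speak of the compounds shown alone.

Working notes on the uridine diphosphate series.

Of the compounds shown here, three have been measured in an in vitro functional assay on 1321-N1 cells for agonist activity at P2Y purinoceptor 6 (Homo sapiens); a lower number here means that less compound is needed, a higher number that more compound is needed for the effect. Compound 1, `O=c1ccn([C@@H]2O[C@H](COP(=O)(O)OP(=O)(O)O)C[C@H]2O)c(=O)[nH]1`, gives 2500 nM in this assay. Compound 2, `Cn1c(=O)ccn([C@@H]2O[C@H](COP(=O)(O)OP(=O)(O)O)[C@@H](O)[C@H]2O)c1=O`, gives 3300 nM in this assay. Compound 3, `CCCCCCSc1ccn([C@@H]2O[C@H](COP(=O)(O)OP(=O)(O)O)[C@@H](O)[C@H]2O)c(=O)n1`, gives 4900 nM in this assay. The gap from compound 3 to compound 2 and the gap from compound 3 to compound 1 both fall within the usual scatter of repeated measurements, so compound 3 is not separated from either of the other two on the numbers shown; the three compounds differ at several places at once, and no single step between measured compounds is available.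

The next compound in the series is compound 4, `O=C(O)CSc1ccn([C@@H]2O[C@H](COP(=O)(O)OP(=O)(O)O)[C@@H](O)[C@H]2O)c(=O)n1`. It differs from compound 3 in one place: carboxy in place of pentyl on a saturated chain carbon bound to a sulfur. Among the measured compounds shown here, no measured pair shows what this change does, so the expectation rests only on the level of compound 3 in this assay. No step beyond the scatter is expected in either direction; the step from compound 3 to compound 4 is estimated as a 1.2-fold lower number from compound 3 to compound 4 (0.09 log units; within the scatter). For compound 4 in this assay the estimate is 4000 nM, with a range from 1500 nM to 12000 nM, and the measured value is awaited.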

Compound 4, half-maximal effective concentration: 1700 nM
The estimate for compound 4 lay 2.4-fold (0.37 log units) above the measured number; the measured number falls inside the stated range.
By their numbers in this assay, from the lowest: compounds 4, 1, 2 and 3 (each within the scatter of the next, the first and the last beyond it).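

In this assay, carboxy in place of pentyl on a saturated chain carbon bound to a sulfur gives a 2.9-fold lower number from compound 3 to compound 4 (0.46 log units; beyond the scatter). Among the compounds shown here, this is the first step that can be read at a single place, and it is a modest one that lies beyond the scatter. It shows that the number responds to the group carried on the sulfur, and that the hexyl chain is not required to reach this level: the (carboxymethyl)sulfanyl group, with a hydrogen-bond donor and acceptor that hexylsulfanyl lacks, gives the lower number. Nothing available on these compounds accounts for the step.

Still open, from the compounds shown here alone, is whether the lower number goes with the carboxylic acid itself or with the shorter chain, as this single step changes both at once; a methyl group on the sulfur, or a methyl ester or primary amide in place of the acid, would separate the two. Also open, going by these compounds, is whether the same change gives a similar step on the core of compound 1 or compound 2, as a single pair cannot show how far it carries.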